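This account rests on a few compounds, and the source may have more. Where it says the series, first, only, none or still open, it means among the compounds named here.

In a functional assay on MCF7 cells (Homo sapiens) for inhibition, read by sulforhodamine B assay, with a stated time of 72 h (on this read-out lower numbers stand for stronger inhibition of growth and higher numbers for weaker inhibition of growth), compound 1 (`CN1CCN(C(=O)/C=C/c2ccncc2-c2ccc3ccccc3c2)CC1`) gives only a limit, > 10000 nM. Compound 2 (`CNC(=O)/C=C/c1ccncc1-c1ccc2ccccc2c1`) gives 9340 nM in this assay, and compound 3 (`CCOC(=O)/C=C/c1ccncc1-c1ccc2cc[nH]c2c1`) gives 6880 nM, so these two numbers lie within the scatter of each other. Compound 4 (`CNC(=O)CCc1ccncc1-c1ccc2ccccc2c1`) is related to compound 2 by one change, 2-(methylcarbamoyl)ethyl in place of 2-(methylcarbamoyl)ethenyl on an aromatic carbon. Within the data shown here, the only measured step in the set is an at least 1.0-fold lower number from compound 1 to compound 2 (0.02 log units; that floor lies within the scatter). That step concerns the group on the carbonyl carbon, not the chain that changes here, and it does not leave the scatter. The ceiling of the measurements also bears on the case: the limit of > 10000 nM in this assay, at which 1 of the 3 values shown sits. Starting from compound 2 at 9340 nM, and with no measured step touching that chain, no step beyond the scatter is expected in this assay. The estimated step is a 1.0-fold higher number from compound 2 to compound 4 (0.01 log units; within the scatter). For compound 4, the expected value is 9500 nM, with an estimated range from 4000 nM to 20000 nM.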

Compound 4, concentration for 50% growth inhibition: > 10000 nM
Compound 4 gave a limit, no number (the forecaster's own chance of this, stated with the estimate: 40%); middle value at least 1.0-fold (0.02 log units) away from the limit.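

In this assay, among these compounds, the earlier step concerned only the group on the carbonyl carbon, whereas the first step on the chain itself, on an aromatic carbon opposite the ring nitrogen, is an at least 1.0-fold higher number from compound 2 to compound 4 (0.02 log units; that floor lies within the scatter). Compound 4 gives only a limit, > 10000 nM, so this step has a floor but no readable size, and the change from 2-(methylcarbamoyl)ethenyl to 2-(methylcarbamoyl)ethyl brings no measurable gain in growth inhibition. The change places a second compound at the ceiling of the measurements: the limit of > 10000 nM in this assay, at which 2 of the 4 values shown sit.

On these data alone, whether compound 4 lies just past this limit or far past it remains open. Also open, as far as these compounds go, is how an amine, a carboxylic acid or a longer chain on this aromatic carbon would read on the shared core.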